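From Methylamino to Ethylamino in a Short Series

A few compounds are considered here, and "the series" means these few. Any claim that something is new, unique, unknown or untested is made for them only; others in the source may bear on it.

In an ADME assay on HaCaT cells (Homo sapiens) for cytotoxicity, read by MTT assay, with a stated time of 72 h (a lower number here means a stronger inhibitor, a higher number a weaker inhibitor), compound 3 (`CNC1=CC(=O)C=C(C(C)(C)C)C1=O`) gives 10000 nM and compound 1 (`CCCCNC1=CC(=O)C=C(C(C)(C)C)C1=O`) gives 11000 nM on the same core, with a 1.1-fold lower number from compound 1 to compound 3 (0.04 log units; within the scatter) lying within the scatter. Compound 2 (`CCCCCCCCNC1=CC(=O)C=C(C(C)(C)C)C1=O`) gives 30000 nM and stands apart from that pair, with a 2.7-fold higher number from compound 1 to compound 2 (0.44 log units; beyond the scatter) and a 3.0-fold lower number from compound 2 to compound 3 (0.48 log units; beyond the scatter) as modest steps beyond the scatter.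

Compound 4 (`CCNC1=CC(=O)C=C(C(C)(C)C)C1=O`) has not yet been measured. It differs from compound 3 by methyl in place of hydrogen on a saturated chain carbon bound to an amine nitrogen in one place: methyl in place of hydrogen on a saturated chain carbon bound to an amine nitrogen, which reads as methylamino to ethylamino.

Two measured steps at this chain bear on the change. Between methyl and butyl, a larger difference than the one in question, a 1.1-fold lower number from compound 1 to compound 3 (0.04 log units; within the scatter) shows no separation beyond the scatter. Only the longest chain, octyl, reaches beyond it, in a 3.0-fold lower number from compound 2 to compound 3 (0.48 log units; beyond the scatter) of modest size. Ethyl is far shorter than octyl, so no step beyond the scatter is expected in this assay here. The expected outcome is a 1.1-fold higher number from compound 3 to compound 4 (0.02 log units; within the scatter) and no more than that. Compound 4 is expected at 10500 nM (estimated range 5500 nM to 20000 nM).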

Compound 4, half-maximal inhibitory concentration: 30000 nM
Compound 4: middle estimate off by 2.9-fold (0.46 log units), on the low side, and the stated range ends below it.
By their numbers in this assay, from the lowest: compounds 3 and 1 (each within the scatter of the next); then compounds 2 and 4 (each within the scatter of the next).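

In this assay, among the compounds shown here, the smallest lengthening of the chain is not a silent change: the single methyl on the saturated chain carbon bound to the amine nitrogen gives a 3.0-fold higher number from compound 3 to compound 4 (0.48 log units; beyond the scatter), whereas the earlier compounds had suggested that only the longest chain moved the number. The ethylamino compound also falls with the octyl compound, with no change at the digits printed from compound 2 to compound 4 (within the scatter), and apart from the butyl compound, with a 2.7-fold higher number from compound 1 to compound 4 (0.44 log units; beyond the scatter), so the numbers do not follow chain length across the four compounds: the methyl and butyl chains group together, as do the ethyl and octyl chains, and compound 1 and compound 4 are the ones that go against any steady rise. No supporting measurement bears on this uneven pattern, so the data offer no account of it.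

The compounds shown leave open where a propyl, pentyl or hexyl chain would fall, and so whether this uneven pattern would persist along the chain. They also leave open whether a branched chain such as isopropyl, or a chain ending in a hydroxyl group, would group with compound 3 or with compound 2.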